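The compounds below may be only part of what the source reports. "The series", "measured", "known", "first", "only" and "open" are said of these compounds alone.

Compound 1 `Nc1ncnc2c1nc(NCCCCNC(=O)CI)n2[C@@H]1O[C@H](COP(=O)(O)OP(=O)(O)OP(=O)(O)O)[C@@H](O)[C@H]1O` and compound 2 `CN(CCCN(C)C(=O)CCCNc1ncnc2c1ncn2[C@@H]1O[C@H](COP(=O)(O)OP(=O)(O)OP(=O)(O)O)[C@@H](O)[C@H]1O)C(=O)CCCNC(=O)CI` were both tested in an assay on isolated protein for inhibition of hexokinase-3 (Rattus norvegicus), with a stated time of 6 h, tested at 10 mM; a lower number here means less inhibition, a higher number more inhibition at the concentration tested (going by the name of the read-out). Compound 1 gives 0% there, and compound 2 gives 0%; the two stand level at the digits shown, with nothing between them beyond the usual scatter. Compound 3 `Nc1ncnc2c1nc(NCCCCCCCCNC(=O)CI)n2[C@@H]1O[C@H](COP(=O)(O)OP(=O)(O)OP(=O)(O)O)[C@@H](O)[C@H]1O` has not yet been measured in this assay. It differs from compound 1 by 4-(((iodomethyl)carbonyl)amino)butyl in place of ((iodomethyl)carbonyl)amino on a saturated chain carbon, four bonds along the chain from a nitrogen on an aromatic ring. With both measured compounds at the bottom of the read-out, the expected step of no change at the digits printed from compound 1 to compound 3 (within the scatter) is none beyond the scatter. Compound 3 is therefore expected to give 0%, within a range from 0% to 10%.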

Compound 3, a percentage reported as inhibition, at one concentration (the size of the read-out at that concentration, not a potency): 0%
Beside the measured number, compound 3's estimate shows no gap at the digits printed; the measured number falls inside the stated range.
By their numbers in this assay, from the lowest: compounds 1, 2 and 3 (each within the scatter of the next).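

In this assay, putting 4-(((iodomethyl)carbonyl)amino)butyl in place of ((iodomethyl)carbonyl)amino on a saturated chain carbon, four bonds along the chain from a nitrogen on an aromatic ring, gives no change at the digits printed from compound 1 to compound 3 (within the scatter). At this position, then, extending the chain while keeping the same end group leaves the read-out at the bottom. Nothing available explains this result.

With the read-out at the bottom for both compounds, any effect of chain length remains hidden. From the compounds shown here alone, whether an amine or a carboxylic acid at the end of this chain would register any inhibition remains open.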